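The compounds below may be only part of what the source reports. "The series", "measured", "known", "first", "only" and "open" are said of these compounds alone.

Compound 1 `CC(=O)N1CCc2c(c(-c3ccc(Br)cc3)nn2CC(O)CN2CCC(n3c(O)nc4ccccc43)CC2)C1` and compound 2 `CC(=O)N1CCc2c(c(-c3ccc(Br)cc3)nn2CC(O)CN2CCC(n3c(O)nc4ccc(Cl)cc43)CC2)C1` share one core and differ in a single place: hydrogen in place of chloro on an aromatic carbon. In an assay on isolated protein for inhibition of cathepsin S (Homo sapiens) (a higher number here means a weaker inhibitor, a lower number a stronger inhibitor), compound 2 gives 120 nM, and compound 1 gives 80 nM. That step, a 1.5-fold lower number from compound 2 to compound 1 (0.18 log units; within the scatter), is small enough that the two numbers cannot be told apart with confidence. Compound 3 `CS(=O)(=O)N1CCc2c(c(-c3ccc(C(F)(F)F)cc3)nn2CCCN2CCC(n3c(O)nc4ccc(Cl)cc43)CC2)C1` is built on a different core; how that core differs from the core of compound 2 is not broken down here. In this assay compound 3 gives 30 nM, the lowest number among the three measured compounds, and its distance from compound 1 and from compound 2 lies beyond the usual scatter.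

Compound 4 `CS(=O)(=O)N1CCc2c(c(-c3ccc(C(F)(F)F)cc3)nn2CCCN2CCC(n3c(O)nc4ccccc43)CC2)C1` stands to compound 3 exactly as compound 1 stands to compound 2: hydrogen in place of chloro on an aromatic carbon. This is the same change as the one already measured, made at the same place, on the core of compound 3 rather than the core of compound 2. Among the measured compounds shown here, since the earlier step was a 1.5-fold lower number from compound 2 to compound 1 (0.18 log units; within the scatter), a step of similar, modest size is expected here as well, with an estimated 1.4-fold lower number from compound 3 to compound 4 (0.13 log units; within the scatter) from compound 3 to compound 4 in this assay, resting on the one measured pair alone. On that basis compound 4 is expected to give about 22 nM in this assay, with a likely range from 10 nM to 50 nM.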

Compound 4, half-maximal inhibitory concentration: 50 nM
Compound 4: the middle estimate sits 2.3-fold (0.36 log units) below what was measured; low and high end bracket the measured number.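

In this assay, hydrogen in place of chloro on the core of compound 3 gives a 1.7-fold higher number from compound 3 to compound 4 (0.22 log units; within the scatter), so this step, like the earlier one, is too small to be read as a real change. Among the compounds shown here, the two steps point in opposite directions as printed, yet the gap between them is no larger than two such steps can show by scatter alone: the same change on two cores in this assay, a 1.5-fold lower number (0.18 log units; within the scatter) from compound 2 to compound 1 and a 1.7-fold higher number (0.22 log units; within the scatter) from compound 3 to compound 4, 2.5-fold (0.40 log units) apart, within the scatter of two such steps This shows that going from 6-chloro-2-hydroxy-1H-benzimidazol-1-yl to 2-hydroxy-1H-benzimidazol-1-yl has no discernible effect on either of these two cores and gives no grounds for saying that the outcome depends on the core, but with only two pairs, it does not show that the change would behave the same way on other cores.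

The compounds shown leave open whether a different group at this place, such as a fluoro, a methoxy or a nitrile, would give a step that stands clear of the scatter. They also leave open how the same change would read on a core carrying an amine or a carboxylic acid in place of the trifluoromethyl group.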